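Following Compound 3 to a Trifluoromethyl Analogue

The compounds below may be only part of what the source reports. "The series", "measured", "known", "first", "only" and "open" are said of these compounds alone.

Compound 1 `COc1ccc(-c2c(Nc3ccc(C)c(O)c3)c3ccccc3oc2=O)cc1`: 9750 nM
Compound 2 `COc1ccc(-c2c(Nc3ccc(F)cc3)c3ccc(OC)cc3oc2=O)cc1`: "not determined" (no result reported)
Compound 3 `CCOc1ccc(Nc2c(-c3ccc(OC)cc3)c(=O)oc3cc(OC)ccc23)cc1`: 36100 nM

In a functional assay on PANC-1 cells (Homo sapiens) for antiproliferative activity, read by MTT assay, with a stated time of 48 h (a lower number here means a stronger inhibitor, a higher number a weaker inhibitor), compound 3 gives 36100 nM, the higher of the two numbers available and so the weaker result. Compound 1 gives 9750 nM, and this gap lies beyond the usual scatter. Compound 2 offers no guide, since no result was reported for it.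

The next compound is compound 4 `COc1ccc(-c2c(Nc3cccc(C(F)(F)F)c3)c3ccc(OC)cc3oc2=O)cc1`. It carries 3-(trifluoromethyl)phenyl in place of 4-ethoxyphenyl on a nitrogen on an aromatic ring. Within the data shown here, no measured pair of compounds differs in only one place, so the data give no direct size for such a change. Among the measured compounds shown here, compound 1 at 9750 nM shows only that a related compound can reach a lower number than compound 3, so a small expected shift downward seems reasonable. In this assay, the estimated change is a 1.8-fold lower number from compound 3 to compound 4 (0.26 log units; within the scatter), which may not clear the scatter. For compound 4 the estimated value is 20000 nM, with an expected range of 7000 nM to 60000 nM.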

Compound 4, half-maximal inhibitory concentration: 39500 nM
Compound 4: middle estimate off by 2.0-fold (0.30 log units), on the low side; the range from low to high includes it.
By their numbers in this assay, from the lowest: compound 1; then compounds 3 and 4 (each within the scatter of the next).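

Among these compounds, this is the first step in which only one place changes, and in this assay it reads a 1.1-fold higher number from compound 3 to compound 4 (0.04 log units; within the scatter). Putting 3-(trifluoromethyl)phenyl in place of 4-ethoxyphenyl on this nitrogen therefore leaves the number within the usual scatter, even though the leaving group holds an oxygen and a hydrogen-bond acceptor, while the entering group holds fluorine and no acceptor. No measurement in hand bears on why these two groups read alike.

Still open, going by these compounds, is whether any group at this nitrogen can move the number beyond the scatter, since one step on one pair says little about the position as a whole. A phenyl ring here carrying an amine or a carboxylic acid, or a longer chain in place of the ethoxy, would test this on the same core.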